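Trifluoromethoxy step from compound 3 to compound 4

This account rests on a few compounds, and the source may have more. Where it says the series, first, only, none or still open, it means among the compounds named here.

Among the compounds with values here, three compounds have numbers so far in a functional assay on DU-145 cells (Homo sapiens) for antiproliferative activity, read by propidium iodide staining, with a stated time of 96 h (on this read-out higher numbers stand for weaker inhibition and lower numbers for stronger inhibition), and they form the only basis for this step. Compound 1 (`CC(O)(CSc1cccc(S(F)(F)(F)(F)F)c1)C(=O)Nc1ccc(S(F)(F)(F)(F)F)cc1`) gives 17300 nM in this read-out, compound 2 (`CC(O)(CSc1cc(C(F)(F)F)cc(C(F)(F)F)c1)C(=O)Nc1ccc(S(F)(F)(F)(F)F)cc1`) gives 29700 nM and compound 3 (`CC(O)(CS(=O)(=O)c1cccc(S(F)(F)(F)(F)F)c1)C(=O)Nc1ccc(S(F)(F)(F)(F)F)cc1`) gives 34000 nM as its value. Compound 3 stands within the scatter of both compound 2 and compound 1, so the three numbers cannot be ranked.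

Compound 4 (`CC(O)(CS(=O)(=O)c1cccc(OC(F)(F)F)c1)C(=O)Nc1ccc(S(F)(F)(F)(F)F)cc1`) keeps the rest of compound 3 and changes one group: a group of 5 heavy atoms (1 carbon, 1 oxygen, 3 fluorine; no ring) in place of a group of 6 heavy atoms (5 fluorine, 1 sulfur; no ring), on an aromatic carbon (trifluoromethoxy enters on an aromatic carbon of a six-membered aromatic ring of carbon only, meta to a large group). Within the data shown here, the series offers no measured step between compounds that differ in one place, so this change has no direct precedent. The structures measured so far differ, yet their values remain within the scatter of each other. No step beyond the scatter is therefore expected in this assay. The anchor is compound 3 at 34000 nM in this comparison. The estimated step of a 1.1-fold lower number from compound 3 to compound 4 (0.05 log units; within the scatter) is expected to stay within the scatter. For compound 4 the expected value is 30000 nM (estimated range 13000 nM to 70000 nM).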

Compound 4, half-maximal inhibitory concentration: 26500 nM
Compound 4: the middle estimate sits 1.1-fold (0.05 log units) above what was measured; the measured number falls inside the stated range.
By their numbers in this assay, from the lowest: compounds 1, 4, 2 and 3 (each within the scatter of the next).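

In this assay, the exchange at this aromatic carbon, meta to a large group, gives a 1.3-fold lower number from compound 3 to compound 4 (0.11 log units; within the scatter). Within the data shown here, this is the first step that can be read at a single place, and it shows that the group of 6 heavy atoms (5 fluorine, 1 sulfur) and trifluoromethoxy cannot be told apart here, even though the count goes from 0 hydrogen-bond acceptors in the leaving group to 1 hydrogen-bond acceptor in the entering one. No measurement on hand offers an explanation for this result.

As far as these compounds go, one exchange at one position does not show how much this position tolerates, so it remains open whether an amine, a carboxylic acid or a nitrile on the same aromatic carbon would give a step beyond the scatter. From the compounds shown here alone, it also remains open whether trifluoromethoxy would give a similarly small step on the thioether linker of compound 1, or whether any change to the shared core would move the number beyond the scatter.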